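Ring substituent swap on the benzyl group of compound 2

A few compounds are considered here, and "the series" means these few. Any claim that something is new, unique, unknown or untested is made for them only; others in the source may bear on it.

Compound 2 `OC[C@H]1O[C@@H](n2cnc3c(NCc4cccc(F)c4)ncnc32)[C@H](O)[C@@H]1O` stands lowest of the three measured numbers in a functional assay on HL-60 cells (Homo sapiens) for antiproliferative activity, with a stated time of 72 h (a lower number here means a stronger inhibitor, a higher number a weaker inhibitor), giving 920 nM. Compound 1 `OC[C@H]1O[C@@H](n2cnc3c(NCc4ccccc4F)ncnc32)[C@H](O)[C@@H]1O` gives 3200 nM in this assay, so the step from 2-fluorophenyl to 3-fluorophenyl reads a 3.5-fold lower number from compound 1 to compound 2 (0.54 log units; beyond the scatter). Compound 3 `OC[C@H]1O[C@@H](n2cnc3c(NCc4ccccc4Br)ncnc32)[C@H](O)[C@@H]1O` gives 6600 nM, which is a 7.2-fold higher number from compound 2 to compound 3 (0.86 log units; beyond the scatter) and, against compound 1, a 2.1-fold higher number from compound 1 to compound 3 (0.31 log units; beyond the scatter).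

Compound 4 `COc1cccc(CNc2ncnc3c2ncn3[C@@H]2O[C@H](CO)[C@@H](O)[C@H]2O)c1` differs from compound 2 by methoxy in place of fluoro on an aromatic carbon. Of the measured steps, only the swap from compound 1 to compound 3 changes a group on the aromatic carbon itself, and it gave a 2.1-fold higher number from compound 1 to compound 3 (0.31 log units; beyond the scatter), a modest weakening when a larger group replaced fluoro. Nothing measured shows methoxy on this ring, and the site here differs from that of compound 3, so the transfer is loose. A modest step is therefore expected in this assay, more likely towards a higher number than a lower one, with a real chance of no step beyond the scatter.

For compound 4 the estimate is 1500 nM, within 450 nM to 5000 nM, which means an expected step of a 1.6-fold higher number from compound 2 to compound 4 (0.21 log units; within the scatter).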

Compound 4, half-maximal inhibitory concentration: 4900 nM
Compound 4: the middle estimate sits 3.3-fold (0.51 log units) below what was measured; measured number inside the range.
By their numbers in this assay, from the lowest: compound 2; then compounds 1, 4 and 3 (each within the scatter of the next, the first and the last beyond it).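

In this assay, for the compounds shown here, the change from 3-fluorobenzyl to 3-methoxybenzyl is the first reading of a group swap at this one ring place with the place held fixed, and the step is clear (a 5.3-fold higher number from compound 2 to compound 4 (0.73 log units; beyond the scatter)). The number of compound 2 therefore does not follow from having a group at this place alone: it depends on which group is there, at least for fluoro and methoxy. Compound 4 does not stand apart from the two compounds carrying a halogen on the other ring place (a 1.5-fold higher number from compound 1 to compound 4 (0.19 log units; within the scatter); a 1.3-fold lower number from compound 3 to compound 4 (0.13 log units; within the scatter)), which leaves compound 2 as the only one of the four whose steps to all the others lie beyond the scatter. Nothing given here bears on why methoxy and fluoro read so differently at this place.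

Still open, going by these compounds, is whether fluoro is unusual at this place or whether other groups on the same aromatic carbon, such as chloro, hydroxyl, an amine or a longer ether chain like ethoxy, would stay near compound 2 or near compound 4. On these data alone, with one methoxy compound, it also remains open whether the step depends on the oxygen or on the added carbon.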